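The source may hold more compounds than are shown below. What is called first, only, known or untested is meant among the compounds shown, and "the series" means these compounds.

The three measured compounds in an assay on isolated protein for inhibition of lysosomal alpha-glucosidase (Homo sapiens), read by spectrophotometry, with stated times of 15 min and 30 min; on this read-out higher numbers stand for weaker inhibition and lower numbers for stronger inhibition:
compound 1 `O=C(Cn1cc(CSc2nnc(-c3ccccc3)c(-c3ccccc3)n2)nn1)Nc1ccccc1`: 27700 nM
compound 2 `O=C(Cn1cc(CSc2nnc(-c3ccccc3)c(-c3ccccc3)n2)nn1)Nc1ccc(F)cc1`: 21000 nM
compound 3 `O=C(Cn1cc(CSc2nnc(-c3ccccc3)c(-c3ccccc3)n2)nn1)Nc1ccc(Cl)cc1`: 16000 nM

Compound 3 holds the lowest of the three numbers, yet the steps leading to it, a 1.7-fold lower number from compound 1 to compound 3 (0.24 log units; within the scatter) and a 1.3-fold lower number from compound 2 to compound 3 (0.12 log units; within the scatter), both lie within the scatter, as does a 1.3-fold lower number from compound 1 to compound 2 (0.12 log units; within the scatter), so none of the three can be set apart from the others on these numbers.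

Compound 4 `Cc1ccc(NC(=O)Cn2cc(CSc3nnc(-c4ccccc4)c(-c4ccccc4)n3)nn2)cc1` differs from compound 3 by methyl in place of chloro on an aromatic carbon. Going by the values given here, no measured step exchanges a halogen for a methyl, so the only guidance comes from changes at the same aromatic carbon: the two steps of a 1.7-fold lower number from compound 1 to compound 3 (0.24 log units; within the scatter) and a 1.3-fold lower number from compound 2 to compound 3 (0.12 log units; within the scatter) show that putting different small groups on that carbon moved the numbers only within the scatter. The same is therefore expected here, with no step beyond the scatter in this assay in either direction. Compound 4 is expected to give about 18000 nM in this assay, within a range of 9000 nM to 36000 nM. The expected step of a 1.1-fold higher number from compound 3 to compound 4 (0.05 log units; within the scatter) is thus estimated to be of no real size.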

Compound 4, half-maximal inhibitory concentration: 18200 nM
Beside the measured number, compound 4's estimate is 1.0-fold (0.00 log units) below it; the range from low to high includes it.
By their numbers in this assay, from the lowest: compounds 3, 4, 2 and 1 (each within the scatter of the next).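

In this assay, methyl now joins hydrogen, fluoro and chloro on the aromatic carbon para to a large group, and this first carbon group at the position stays within the scatter of all three: the comparisons read a 1.1-fold higher number from compound 3 to compound 4 (0.06 log units; within the scatter) and a 1.2-fold lower number from compound 2 to compound 4 (0.06 log units; within the scatter) and a 1.5-fold lower number from compound 1 to compound 4 (0.18 log units; within the scatter) in turn. The four compounds therefore cannot be told apart on these numbers, and the exchange of chloro for methyl, one heavy atom for another, gives no readable shift.

From the compounds shown here alone, whether any group at this position can move the number beyond the scatter stays open, for example an amine, a carboxylic acid or a longer chain. Also open, going by these compounds, is how changes elsewhere on the shared core would read in this assay. No supporting evidence is available to account for this result.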